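Replacing the naphthyl group on the shared core

The source may report more compounds than this note shows. Statements on the series, on what has been measured and on what is new or still open speak of the compounds shown alone.

Measured so far:
compound 1, `COc1cc(N2C(N)=C(C#N)C(c3ccc(OC)c4ccccc34)C3=C2CC(C)(C)CC3=O)cc(OC)c1OC`: 30%
compound 2, `COc1ccccc1C1C(C#N)=C(N)N(c2cc(OC)c(OC)c(OC)c2)C2=C1C(=O)CC(C)(C)C2`: 65%
Not yet measured:
compound 3, `COc1cc(N2C(N)=C(C#N)C(c3cccs3)C3=C2CC(C)(C)CC3=O)cc(OC)c1OC`

In a functional assay on Ehrlich cells (Mus musculus) for cytotoxicity, tested at 25 ug/mL (a higher number here means a stronger effect of the compound at the concentration tested, a lower number a weaker effect), compound 1 gives 30%, the lowest of the two numbers shown; its nearest neighbour is compound 2, which gives 65%. Within the data shown here, the only measured step that bears on the question here is a number 35 percentage points higher from compound 1 to compound 2 (beyond the scatter), brought about by 2-methoxyphenyl in place of 4-methoxynaphthalen-1-yl on a saturated ring carbon. Compound 3 differs from compound 1 by thiophen-2-yl in place of 4-methoxynaphthalen-1-yl on a saturated ring carbon. Among the measured compounds shown here, both changes remove 4-methoxynaphthalen-1-yl from the same saturated ring carbon and put a single-ring aromatic group in its place, but thiophen-2-yl is not 2-methoxyphenyl, and no measured step shows that group itself. For the measured compounds named here, a rise in this assay beyond the scatter is therefore expected, though with a wide range, and somewhat smaller than the one measured step. Compound 3 is expected to give about 50%, between 25% and 75%, an estimated step of a number 20 percentage points higher from compound 1 to compound 3 (beyond the scatter).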

Compound 3, a percentage reported as activity, at one concentration (the size of the read-out at that concentration, not a potency): 10%
Beside the measured number, compound 3's estimate is 40 percentage points above it, outside the stated range (below it).
By their numbers in this assay, from the lowest: compound 3; then compound 1; then compound 2.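

In this assay, the change to thiophen-2-yl on the saturated ring carbon gives a number 20 percentage points lower from compound 1 to compound 3 (beyond the scatter) and so shows that removing 4-methoxynaphthalen-1-yl from this position does not by itself raise the read-out. Thiophen-2-yl in place of 2-methoxyphenyl gives a number 55 percentage points lower from compound 2 to compound 3 (beyond the scatter) at the same carbon, so in these compounds the direction of the change depends on the single-ring aromatic group that enters, with compound 2 above compound 1 and compound 3 below it. No measurement shown here accounts for this difference between the two groups.

The compounds shown leave open whether the higher read-out of compound 2 goes with its methoxy group or with its six-membered aromatic ring. A plain phenyl or a furan-2-yl group on this carbon would help to separate these two possibilities.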